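Swapping Bromo for Chloro on the Fused Ring

This account rests on a few compounds, and the source may have more. Where it says the series, first, only, none or still open, it means among the compounds named here.

In a functional assay on Mino cells (Homo sapiens) for cytotoxicity, read by MTT assay, with a stated time of 72 h (on this read-out higher numbers stand for weaker inhibition and lower numbers for stronger inhibition), compound 3 `O=C1N=C(N2N=C(c3ccc(Cl)cc3)CC2c2ccc(Cl)cc2)S/C1=C1\C(=O)Nc2ccc(Br)cc21` gives 730 nM, the lowest of the three numbers seen. Compound 1 `O=C1N=C(N2N=C(c3ccc(Br)cc3)CC2c2ccc(Cl)cc2)S/C1=C1\C(=O)Nc2ccc(Cl)cc21` gives 7400 nM, and compound 2 `O=C1N=C(N2N=C(c3ccc(Cl)cc3)CC2c2ccc(Cl)cc2)S/C1=C1\C(=O)Nc2ccccc21` gives 68200 nM; compound 3 thus stands beyond the scatter from both, nearest to compound 1 and furthest from compound 2. Compound 4 `O=C1N=C(N2N=C(c3ccc(Cl)cc3)CC2c2ccc(Cl)cc2)S/C1=C1\C(=O)Nc2ccc(Cl)cc21` differs from compound 3 by chloro in place of bromo on an aromatic carbon. Among the measured compounds shown here, the only measured step at this place, a 93-fold lower number from compound 2 to compound 3 (1.97 log units; beyond the scatter), shows that placing bromo there changes the number greatly. For the measured compounds named here, no measured pair shows bromo against chloro at this place alone; compound 1 carries chloro there but also bromo on another ring, so its number only hints at a weaker result. Because a 93-fold lower number from compound 2 to compound 3 (1.97 log units; beyond the scatter) came from adding a group rather than exchanging one, a much smaller step is expected in this assay, a modest rise at most, a 2.1-fold higher number from compound 3 to compound 4 (0.31 log units; beyond the scatter). Compound 4 is therefore estimated at 1500 nM, within a range from 500 nM to 5000 nM.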

Compound 4, half-maximal inhibitory concentration: 80700 nM
Estimate against measurement, compound 4: 54-fold (1.73 log units) below; measured number outside the range, above it.
By their numbers in this assay, from the lowest: compound 3; then compound 1; then compounds 2 and 4 (each within the scatter of the next).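

At this place on the fused ring, the gain belongs to bromo and not to halogens in general: the exchange for chloro gives a 110-fold higher number from compound 3 to compound 4 (2.04 log units; beyond the scatter) in this assay, and chloro cannot be told apart from hydrogen, with a 1.2-fold higher number from compound 2 to compound 4 (0.07 log units; within the scatter). The same exchange made on another ring, where compound 1 carries its bromo, points the same way, with an 11-fold higher number from compound 1 to compound 4 (1.04 log units; beyond the scatter), so among these four compounds the two with a single bromo at either place give the lower numbers. Nothing measured here accounts for so sharp a split between two such similar atoms. Open, on these data alone, is whether iodo or fluoro at the fused-ring place would follow bromo or chloro, and what a methyl or an amine would do there. Also open, as far as these compounds go, is whether compound 3 would gain further with bromo on both rings.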